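The source may report more compounds than this note shows. Statements on the series, on what has been measured and on what is new or still open speak of the compounds shown alone.

Working notes on the triazole-linked series. Compound 1 `CCCCCCn1cc(COc2ccc3c(c2)OC(c2ccc(C(C)C)cc2)CC3=O)nn1` carries a hexyl chain on the triazole and an isopropyl on the pendant phenyl; in an ADME assay on cells (Macrophage) for cytotoxicity, read by resazurin assay, with a stated time of 48 h (on this read-out higher numbers stand for lower toxicity in this test and lower numbers for higher toxicity in this test), compound 1 gives "not determined" (no result reported). Compound 3 `CC(C)c1ccc(C2CC(=O)c3ccc(OCc4cn(Cc5ccc(Br)cc5)nn4)cc3O2)cc1` likewise stands without a result: in this assay compound 3 gives "not determined" (no result reported). Among the measured compounds shown here, the one figure comes from compound 2 `CC(C)c1ccc(C2CC(=O)c3ccc(OCc4cn(Cc5ccccc5)nn4)cc3O2)cc1`: in this assay compound 2 gives 23800 nM. Compound 4 `CCCCCCn1cc(COc2ccc3c(c2)OC(c2ccc(OC)cc2)CC3=O)nn1` differs from compound 1 by methoxy in place of isopropyl on an aromatic carbon. With no value for compound 1, the size of the step cannot be anchored; nothing in the data suggests a shift in this assay beyond the usual scatter, in either direction. Compound 4 is expected to read about 25000 nM in this assay, with a range of 8000 nM to 80000 nM.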

Compound 4, half-maximal cytotoxic concentration: 57500 nM
Beside the measured number, compound 4's estimate is 2.3-fold (0.36 log units) below it; the range from low to high includes it.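

Among the compounds shown here, compound 1 gives "not determined" (no result reported) in this assay and no step from it to compound 4 can be read. On these data alone, what the change from 4-isopropylphenyl to 4-methoxyphenyl does to this read-out stays open, and no evidence bears on the result.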